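The source may hold more compounds than are shown below. What is called first, only, known or untested is meant among the compounds shown, and "the series" means these compounds.

In a functional assay on L1210 cells (Mus musculus) (on this read-out lower numbers stand for stronger inhibition and higher numbers for weaker inhibition), compound 2 `CCCCCC#Cc1cn([C@H]2C[C@H](O)[C@@H](CO)O2)c(=O)[nH]c1=O` gives 219 ug/mL, while compound 1 `CC(C)(C)C#Cc1cn(C2O[C@H](CO)[C@@H](O)[C@H]2O)c(=O)[nH]c1=O` gives 300 ug/mL; the two numbers lie within the scatter of each other, so neither compound stands apart on this read-out. Compound 3 `COCC#Cc1cn([C@H]2C[C@H](O)[C@@H](CO)O2)c(=O)[nH]c1=O` has not yet been measured in this assay. It differs from compound 2 by methoxy in place of butyl on a saturated chain carbon bound to a triple-bonded carbon. Among the measured compounds shown here, no measured pair shows this change, so its size is unknown; with both measured numbers already high, little beyond the scatter or a modest move toward weaker inhibition is expected. The expected step is a 1.4-fold higher number from compound 2 to compound 3 (0.14 log units; within the scatter) for compound 3. Compound 3 is estimated at 300 ug/mL, in the range 100 ug/mL to 900 ug/mL.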

Compound 3, concentration for 50% inhibition: 254 ug/mL
The estimate for compound 3 lay 1.2-fold (0.07 log units) above the measured number; low and high end bracket the measured number.
By their numbers in this assay, from the lowest: compounds 2, 3 and 1 (each within the scatter of the next).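

In this assay, among the compounds shown here, methoxy in place of butyl on a saturated chain carbon bound to a triple-bonded carbon gives a 1.2-fold higher number from compound 2 to compound 3 (0.06 log units; within the scatter) and so is the first single-place change read. At this position, the exchange of the all-carbon butyl for the smaller, oxygen-bearing methoxy leaves the read-out within the scatter. Nothing at hand bears on the reason for this result.

From the compounds shown here alone, whether an amine, a carboxylic acid or a longer chain in this place would move the number beyond the scatter stays open. Going by these compounds, whether any group here can reach clearly stronger inhibition also stays open.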